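The source may report more compounds than this note shows. Statements on the series, on what has been measured and on what is new or still open speak of the compounds shown alone.

Among the compounds with values here, compound 2 `Cn1c(=O)c(=O)n(C2CCCC2)c2nc(N/N=C/c3cccc([N+](=O)[O-])c3)ncc21` gives 20300 nM in a functional assay on PC-3 cells (Homo sapiens) for antiproliferative activity, read by MTT assay (a lower number here means a stronger inhibitor, a higher number a weaker inhibitor), one of only two numbers measured so far; compound 1 `Cn1c(=O)c(=O)n(C2CCCC2)c2nc(N/N=C/c3cccc(Cl)c3Cl)ncc21` gives 17200 nM, and the step of a 1.2-fold higher number from compound 1 to compound 2 (0.07 log units; within the scatter) lies within the scatter. Compound 3 `Cn1c(=O)c(=O)n(C2CCCC2)c2nc(N/N=C/c3ccc(F)cc3F)ncc21` differs from compound 2 by 2,4-difluorophenyl in place of 3-nitrophenyl on a carbon with a double bond to nitrogen. Within the data shown here, the single measured step that bears on this change also swapped one aryl group at the same carbon and was a 1.2-fold higher number from compound 1 to compound 2 (0.07 log units; within the scatter), so the expected step of a 1.0-fold lower number from compound 2 to compound 3 (0.01 log units; within the scatter) is none beyond the scatter. Compound 3 is therefore estimated at 20000 nM, with a range from 8000 nM to 50000 nM.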

Compound 3, half-maximal inhibitory concentration: 13200 nM
For compound 3 the middle estimate is 1.5-fold (0.18 log units) above the measured one; the range from low to high includes it.
By their numbers in this assay, from the lowest: compounds 3, 1 and 2 (each within the scatter of the next).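

In this assay, a third aryl group on the carbon with a double bond to nitrogen again leaves the number within the scatter, with a 1.5-fold lower number from compound 2 to compound 3 (0.19 log units; within the scatter) and a 1.3-fold lower number from compound 1 to compound 3 (0.11 log units; within the scatter). The 3-nitrophenyl group has 2 hydrogen-bond acceptors and the 2,4-difluorophenyl group has 0, yet this swap gives no step beyond the scatter, so these three aryl groups cannot be ranked. No measurement shown offers a reason for this result. From the compounds shown here alone, whether an aryl ring bearing an amine or a carboxylic acid, or a longer chain in place of the ring, would move the number beyond the scatter stays open.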